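Extending the acetamido group of compound 3 toward a urea

The source may report more compounds than this note shows. Statements on the series, on what has been measured and on what is new or still open speak of the compounds shown alone.

Compound 1 `Cc1cn([C@@H]2O[C@H](CO[Si](C)(C)C(C)(C)C)[C@@]3(OS(=O)(=O)C=C3NCC(N)=O)[C@H]2O[Si](C)(C)C(C)(C)C)c(=O)n(C)c1=O`: 13500 nM
Compound 2 `Cc1cn([C@@H]2O[C@H](CO[Si](C)(C)C(C)(C)C)[C@@]3(OS(=O)(=O)C=C3NCC(=O)C(=O)N3CCC3)[C@H]2O[Si](C)(C)C(C)(C)C)c(=O)n(C)c1=O`: 84400 nM
Compound 3 `CC(=O)NC1=CS(=O)(=O)O[C@@]12[C@@H](CO[Si](C)(C)C(C)(C)C)O[C@@H](n1cc(C)c(=O)n(C)c1=O)[C@@H]2O[Si](C)(C)C(C)(C)C`: > 200000 nM

In a functional assay on HEL cells (Homo sapiens) (on this read-out higher numbers stand for lower toxicity in this test and lower numbers for higher toxicity in this test), compound 3 gives only a limit, > 200000 nM, and no number. It is the only one of the three at the limit of > 200000 nM in this assay, at which 1 of the 3 values shown sits. The step of an at least 14-fold higher number from compound 1 to compound 3 (1.17 log units; beyond the scatter) and the step of an at least 2.3-fold higher number from compound 2 to compound 3 (0.37 log units; beyond the scatter) both ran toward compound 3, so compound 3 stands at the top of what this assay showed.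

Compound 4 `CCOC(=O)CNC(=O)NC1=CS(=O)(=O)O[C@@]12[C@@H](CO[Si](C)(C)C(C)(C)C)O[C@@H](n1cc(C)c(=O)n(C)c1=O)[C@@H]2O[Si](C)(C)C(C)(C)C` differs from compound 3 in one place: ((ethoxycarbonyl)methyl)amino in place of methyl on a carbonyl carbon. Within the data shown here, no measured step touches the carbonyl carbon of this group, so none bears on it directly. Compound 4 is expected to stay near the limit, with an expected step of a number no higher from compound 3 to compound 4 (the limit leaves the size open), most likely again reported as a limit. The estimate for compound 4 in this assay is 200000 nM, within 70000 nM to 500000 nM.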

Compound 4, half-maximal cytotoxic concentration: 13000 nM
The estimate for compound 4 lay 15-fold (1.19 log units) above the measured number; the whole stated range lies above it.
By their numbers in this assay, from the lowest: compounds 4 and 1 (each within the scatter of the next); then compound 2. At a limit, above all of these: compound 3.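

In this assay, among these compounds, the earlier steps left this carbonyl carbon untouched, and putting ((ethoxycarbonyl)methyl)amino in place of its methyl gives an at least 15-fold lower number from compound 3 to compound 4 (1.18 log units; beyond the scatter). That step starts from a limit and not a number: the limit of > 200000 nM in this assay, at which 1 of the 4 values shown sits.

Compound 4 is not separated from compound 1, with a 1.0-fold lower number from compound 1 to compound 4 (0.02 log units; within the scatter), but it is separated from compound 2, with a 6.5-fold lower number from compound 2 to compound 4 (0.81 log units; beyond the scatter).

The compounds shown leave open whether the ethyl ester or the rest of the new chain goes with this change. A carboxylic acid in place of the ester, or a shorter alkyl chain on the same nitrogen, would speak to that.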